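Replacing Phenyl with Ethyl: Expected Effect on Cytotoxicity

The source may report more compounds than this note shows. Statements on the series, on what has been measured and on what is new or still open speak of the compounds shown alone.

Three compounds share one core and differ only in the group on a single aromatic carbon. Compound 1 `O=C(/C=C/c1ccc2c(c1)B(O)OC2)c1ccc(-c2ccccc2)cc1` carries a phenyl there; in a toxicity assay on WI-38 cells (Homo sapiens) for cytotoxicity, read by MTT assay, with a stated time of 48 h (on this read-out higher numbers stand for weaker inhibition and lower numbers for stronger inhibition), compound 1 gives 18300 nM, the lowest of the two numbers shown. Its nearest neighbour is compound 3 `Cc1ccc(C(=O)/C=C/c2ccc3c(c2)B(O)OC3)cc1` at 22200 nM, and the step of a 1.2-fold higher number from compound 1 to compound 3 (0.08 log units; within the scatter) stays within the scatter. Compound 2 `O=C(/C=C/c1ccc2c(c1)B(O)OC2)c1ccc(I)cc1` is reported in this assay only as a limit, > 100000 nM. The step of an at least 5.4-fold higher number from compound 1 to compound 2 (0.73 log units; beyond the scatter) is larger.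

Compound 4 `CCc1ccc(C(=O)/C=C/c2ccc3c(c2)B(O)OC3)cc1` is not yet measured; it differs from compound 1 by ethyl in place of phenyl on an aromatic carbon. Since ethyl is a short chain like methyl, the methyl step bears most on it, and the expected step is a 1.2-fold higher number from compound 1 to compound 4 (0.08 log units; within the scatter), within the scatter. Compound 4 is expected to give 22000 nM, between 10000 nM and 50000 nM.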

Compound 4, half-maximal inhibitory concentration: 20600 nM
For compound 4 the middle estimate is 1.1-fold (0.03 log units) above the measured one; the measured number falls inside the stated range.
By their numbers in this assay, from the lowest: compounds 1, 4 and 3 (each within the scatter of the next). At a limit, above all of these: compound 2.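

The step of a 1.1-fold higher number from compound 1 to compound 4 (0.05 log units; within the scatter) and the step of a 1.1-fold lower number from compound 3 to compound 4 (0.03 log units; within the scatter) show that in this assay ethyl cannot be told apart from phenyl or methyl at this position, so neither the size of the group nor the extra carbon on the methyl shifts the number here. The step of an at least 4.8-fold lower number from compound 2 to compound 4 (0.68 log units; beyond the scatter) puts ethyl on the same side as those two groups, apart from iodo. Compound 2 is reported only as a limit: the limit of > 100000 nM in this assay, at which 1 of the 4 values shown sits.

The groups shown are carbon groups and iodo, so what an amine, a carboxylic acid or a longer chain such as butyl would do at this position stays open. Why iodo alone stands apart also stays open.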